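The source may hold more compounds than are shown below. What is called first, only, known or untested is meant among the compounds shown, and "the series" means these compounds.

Working notes on a small series of protected sugar-derived scaffolds, all read in a functional assay on HL-60 cells (Homo sapiens) for antiproliferative activity, read by MTT assay; on this read-out lower numbers stand for stronger inhibition and higher numbers for weaker inhibition.

Compound 1 `O[C@@H]1[C@@H](O)[C@H](Cc2ccccc2)O[C@H](COCc2ccccc2)[C@H]1O` carries a benzyl on the ring carbon and free hydroxy groups; in this assay compound 1 is recorded as "not active" (no number reported). Compound 3 `CC[C@H]1O[C@H](COCc2ccccc2)[C@@H](OCc2ccccc2)[C@H](OCc2ccccc2)[C@H]1O` carries an ethyl on the ring carbon with three benzyl-protected positions; in this assay compound 3 is recorded as "not active" (no number reported). Compound 2 `OCCC[C@@H]1O[C@H](COCc2ccccc2)[C@@H](OCc2ccccc2)[C@H](OCc2ccccc2)[C@H]1O` carries a 3-hydroxypropyl chain on the same protected core, and in this assay compound 2 gives 19300 nM. Going by the values given here, compound 2 therefore stands as the only entry with a number; the two other entries carry no single number.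

Compound 4 `CCCCC[C@@H]1O[C@H](COCc2ccccc2)[C@@H](OCc2ccccc2)[C@H](OCc2ccccc2)[C@H]1O` is the next entry to be measured. The change from compound 2 to compound 4 is ethyl in place of hydroxy on a saturated chain carbon, three bonds along the chain from a saturated ring carbon. Among the compounds with values here, no measured pair of this kind exists, so the size of the step must be expected rather than read. Since compound 3, with a plain alkyl chain, is recorded as "not active" (no number reported), the step is expected to go toward weaker inhibition, likely beyond the scatter. The expected step is a 1.8-fold higher number from compound 2 to compound 4 (0.26 log units; within the scatter). Compound 4 is expected to give 35000 nM, within a range of 12000 nM to 100000 nM.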

Compound 4, half-maximal inhibitory concentration: "not active" (no number reported)
The entry for compound 4 holds no number; no gap can be computed for the estimate.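

In this assay, going by these compounds alone, compound 4 is recorded as "not active" (no number reported), so no step from compound 2 can be read. No measurement shown accounts for this result. The compounds shown leave open whether the hydroxy group on the 3-hydroxypropyl chain of compound 2 matters for its activity.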